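A few compounds are considered here, and "the series" means these few. Any claim that something is new, unique, unknown or untested is made for them only; others in the source may bear on it.

In a functional assay on OVCAR-3 cells (Homo sapiens) for antiproliferative activity, read by spectrophotometry, with a stated time of 2 days (on this read-out higher numbers stand for weaker inhibition of growth and lower numbers for stronger inhibition of growth), compound 1 `COc1ccc(C(F)(F)F)cc1Nc1ncc(C(F)(F)F)c(N2Cc3cccc(N(C)S(C)(=O)=O)c3C2)n1` gives > 30000 nM, which is a limit of the assay and not a number. For compound 1 that is the limit of > 30000 nM in this assay, at which 1 of the 3 values shown sits. Two other compounds sharing the core of compound 1 have numerical read-outs: compound 2 `COc1cc(N2CCN(C(C)=O)CC2)ccc1Nc1ncc(C(F)(F)F)c(N2Cc3cccc(N(C)S(C)(=O)=O)c3C2)n1` gives 1600 nM, and compound 3 `CN(c1cccc2c1CN(c1nc(Nc3cccc(Oc4ccccc4)c3)ncc1C(F)(F)F)C2)S(C)(=O)=O`, with no methoxy on its aryl group, gives 24900 nM.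

The next compound is compound 4 `CN(c1cccc2c1CN(c1nc(Nc3ccc(C(F)(F)F)cc3)ncc1C(F)(F)F)C2)S(C)(=O)=O`, which differs from compound 1 at one place: 4-(trifluoromethyl)phenyl in place of 2-methoxy-5-(trifluoromethyl)phenyl on a nitrogen on an aromatic ring. The 4-(trifluoromethyl)phenyl stands in place of the 2-methoxy-5-(trifluoromethyl)phenyl on a nitrogen on an aromatic ring, so the trifluoromethyl stays and the methoxy goes. Within the data shown here, no measured pair isolates this change, so the expectation rests on the values alone. Compound 3, also without the methoxy, still reads only 24900 nM. Compound 2, at 1600 nM, shows that the aryl group can matter, but its substituents are not those of compound 4.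

The expected change in this assay, an at least 1.3-fold lower number from compound 1 to compound 4 (0.13 log units; that floor lies within the scatter), is none beyond the scatter. A result reported only as a limit would also be unsurprising. For compound 4 the estimate is 22000 nM, with an expected range of 8000 nM to 30000 nM.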

Compound 4, concentration for 50% growth inhibition: > 30000 nM
Compound 4 was reported as a limit; the forecaster's own chance of this, stated with the estimate: 40%; middle value at least 1.3-fold (0.13 log units) away from the limit.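

In this assay compound 4 gives > 30000 nM, which is a limit of the assay and not a number. Compound 1 also stands at a limit, so no step between compound 1 and compound 4 can be read: the limit of > 30000 nM in this assay, at which 2 of the 4 values shown sit.

The compounds shown leave open how 4-(trifluoromethyl)phenyl and 2-methoxy-5-(trifluoromethyl)phenyl compare in this assay.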